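The source may report more compounds than this note shows. Statements on the series, on what has been measured and on what is new or still open speak of the compounds shown alone.

Measured so far:
compound 1 `Cn1ncc(Cl)c1-c1cc(C(=O)N[C@H]2CNCC[C@@H]2c2ccc(C(F)(F)F)cc2)oc1Cl` gives 127 nM
compound 2 `C=CC[C@@H]1C[C@@H](c2ccc(Cl)c(Cl)c2)[C@H](NC(=O)c2cc(-c3c(Cl)cnn3C)c(Cl)o2)CN1` gives 12.4 nM

Both numbers come from an assay for inhibition of RAC-alpha serine/threonine-protein kinase (Homo sapiens), read by HTRF, with a stated time of 1 h; on this read-out lower numbers stand for stronger inhibition and higher numbers for weaker inhibition. Compound 2 stands at the lower of the two numbers, which on this read-out means the stronger inhibition; compound 1 sits at a higher number, and the gap between them lies beyond the usual scatter of repeated measurements. The two compounds differ in more than one place, so the gap cannot be tied to any single change.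

Compound 3 `Cn1ncc(Cl)c1-c1cc(C(=O)N[C@@H]2CN[C@H](CC(=O)NC3CCC3)C[C@H]2c2ccc(Cl)c(Cl)c2)oc1Cl` has not yet been measured. It is built from compound 2 by one change: cyclobutylcarbamoyl in place of vinyl on a saturated chain carbon bound to a saturated ring carbon. The group that enters is larger than the one that leaves and brings one hydrogen-bond donor and one hydrogen-bond acceptor with it. Going by the values given here, no measured pair shows this change, so there is nothing to lean on for its size or direction. The expectation is therefore a modest step, most likely toward a somewhat higher number, with wide uncertainty: compound 3 is estimated to give 25 nM, between 5 nM and 120 nM, an expected step of a 2.0-fold higher number from compound 2 to compound 3 (0.30 log units; within the scatter).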

Compound 3, half-maximal inhibitory concentration: 7.98 nM
The estimate for compound 3 lay 3.1-fold (0.50 log units) above the measured number; the range from low to high includes it.
By their numbers in this assay, from the lowest: compounds 3 and 2 (each within the scatter of the next); then compound 1.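

Going by these compounds alone, this is the first pair to probe the place on a saturated chain carbon bound to a saturated ring carbon. In this assay, putting cyclobutylcarbamoyl in place of vinyl gives a 1.6-fold lower number from compound 2 to compound 3 (0.19 log units; within the scatter), so the two compounds cannot be told apart on this read-out. The position therefore accepts a much larger group without a change beyond the scatter: 7 heavy atoms, with a four-membered ring, a hydrogen-bond donor and a hydrogen-bond acceptor, replace 2 heavy atoms of carbon that have no donor or acceptor. There is no measurement here that could explain why the number holds steady.

A single pair cannot show how far this acceptance extends, or whether the cyclobutyl ring or the amide hydrogen contributes anything to the value of compound 3. Also open, going by these compounds, is whether a simple methyl amide, a free carboxylic acid or a primary amine at the same place would stay level with compound 2 or move the number beyond the scatter.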